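Trisubstituted triazine anilines: a fourth aryl amine variant

The source may hold more compounds than are shown below. What is called first, only, known or untested is meant among the compounds shown, and "the series" means these compounds.

Measured so far:
compound 1 `COc1cc(Nc2nnc(Cl)c(Nc3cc(OC)c(OC)c(OC)c3)n2)cc(OC)c1OC` gives 24300 nM in a functional assay on MGC-803 cells (Homo sapiens) for inhibition, read by MTT assay, with a stated time of 48 h; on this read-out lower numbers stand for stronger inhibition and higher numbers for weaker inhibition
compound 2 `COc1cccc(Nc2nnc(Cl)c(Nc3cc(OC)c(OC)c(OC)c3)n2)c1` gives 16500 nM in this assay

Compound 2 holds the lower of the two numbers, with compound 1 close by, and the gap between them sits within the scatter, so the two are not distinguishable on this read-out.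

Compound 3 `COc1cc(Nc2nc(Nc3ccc(C(C)=O)cc3)nnc2Cl)cc(OC)c1OC` is not yet measured. It differs from compound 2 in one place: 4-acetylphenyl in place of 3-methoxyphenyl on a nitrogen on an aromatic ring. Among the measured compounds shown here, no measured pair shows a change of this kind, so no measured step tells what to expect here.

Both measured compounds sit in the same weak range, and compound 3 is expected to stay there; the step of a 1.0-fold lower number from compound 2 to compound 3 (0.01 log units; within the scatter) is expected to fall within the scatter, in neither direction. For compound 3 the estimate is 16000 nM, with a range from 5000 nM to 50000 nM.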

Compound 3, half-maximal inhibitory concentration: 13000 nM
Estimate against measurement, compound 3: 1.2-fold (0.09 log units) above, within the range that was stated.
By their numbers in this assay, from the lowest: compounds 3, 2 and 1 (each within the scatter of the next).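

Putting 4-acetylphenyl in place of 3-methoxyphenyl on this nitrogen on an aromatic ring gives a 1.3-fold lower number from compound 2 to compound 3 (0.10 log units; within the scatter) in this assay. As the only step shown at this position, it indicates that this exchange of aryl groups leaves the read-out in the same weak range, with no change beyond the scatter. Nothing at hand bears on the reason for this result.

As far as these compounds go, whether an amine or a carboxylic acid on this aryl ring would move the number beyond the scatter remains open. So does the effect of a longer chain in place of the acetyl group.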